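The source may report more compounds than this note shows. Statements on the series, on what has been measured and on what is new or still open speak of the compounds shown alone.

Compound 1, with the structure `CCCCCCNc1nc(-c2ccccc2)nc2c1nnn2Cc1ccccc1Cl`, is one of three compounds whose numbers in an assay on Cerebral cortex for displacement of a labelled ligand from adenosine receptor A1 (Bos taurus) (on this read-out higher numbers stand for weaker inhibition and lower numbers for stronger inhibition), are already known: in this assay compound 1 gives 31 nM. Compound 2, with the structure `CCCCCCNc1nc(-c2ccccc2)nc2c1nnn2Cc1ccccc1F`, differs from compound 1 only at one point, (fluoro in place of chloro on an aromatic carbon), and in this assay compound 2 gives 25 nM, so that the step recorded is a 1.2-fold lower number from compound 1 to compound 2 (0.09 log units; within the scatter). Compound 3, with the structure `OCCCNc1nc(-c2ccccc2)nc2c1nnn2Cc1ccccc1Cl`, differs from compound 1 at another point, (hydroxy in place of propyl on a saturated chain carbon, three bonds along the chain from a nitrogen on an aromatic ring); in this assay compound 3 gives 33 nM, and the step recorded is a 1.1-fold higher number from compound 1 to compound 3 (0.03 log units; within the scatter). All three numbers thus sit within the scatter of one another, and none of the compounds can be set apart from the others.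

Compound 4, with the structure `OCCCNc1nc(-c2ccccc2)nc2c1nnn2Cc1ccccc1F`, has not yet been measured. It differs from compound 3 by fluoro in place of chloro on an aromatic carbon, which is the same change, at the same place, as the one from compound 1 to compound 2; among the compounds shown this change occurs in two pairs. Since that earlier change gave a 1.2-fold lower number from compound 1 to compound 2 (0.09 log units; within the scatter), and since compound 3 gives 33 nM, the expected step from compound 3 to compound 4 in this assay is a 1.2-fold lower number from compound 3 to compound 4 (0.09 log units; within the scatter). On that footing compound 4 is estimated to give 27 nM in this assay, with the likely range running from 13 nM to 55 nM.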

Compound 4, inhibition constant: 3.7 nM
Compound 4: middle estimate off by 7.3-fold (0.86 log units), on the high side; measured number below the stated range.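

In this assay, fluoro in place of chloro on the aromatic carbon gives an 8.9-fold lower number from compound 3 to compound 4 (0.95 log units; beyond the scatter), so this change does not carry over unchanged from one core to the other: the same change on two cores in this assay, a 1.2-fold lower number (0.09 log units; within the scatter) from compound 1 to compound 2 and an 8.9-fold lower number (0.95 log units; beyond the scatter) from compound 3 to compound 4, 7.2-fold (0.86 log units) apart, beyond the scatter of two such steps

Hydroxy in place of propyl on the chain gives a 6.8-fold lower number from compound 2 to compound 4 (0.83 log units; beyond the scatter), and this change likewise depends on the core that carries it: the same change on two cores in this assay, a 1.1-fold higher number (0.03 log units; within the scatter) from compound 1 to compound 3 and a 6.8-fold lower number (0.83 log units; beyond the scatter) from compound 2 to compound 4, 7.2-fold (0.86 log units) apart, beyond the scatter of two such steps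

Both gaps rest on the same four compounds and so record a single finding, that the fluoro and hydroxy changes do not act independently here, but they do not show why this is so or whether it holds beyond these four compounds.

The compounds shown leave open whether a methoxy or an amine in place of the hydroxy, or a longer chain carrying the hydroxy, would behave in the same way alongside the 2-fluorobenzyl group. They also leave open whether bromo or a plain hydrogen in place of the fluoro would keep the low number of compound 4, which would tell whether this result is specific to fluoro.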